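The source may hold more compounds than are shown below. What is called first, only, known or untested is meant among the compounds shown, and "the series" means these compounds.

Measured in a functional assay on MCF7 cells (Homo sapiens); a higher number here means a weaker inhibitor of growth, a lower number a stronger inhibitor of growth:
- compound 1 `O=S(=O)(/C=C/c1ccccc1)Cc1ccc(Nc2ncnc3ccccc23)cc1`: 74000 nM
- compound 2 `N#Cc1ccc(/C=C/S(=O)(=O)Cc2ccc(Nc3ncnc4ccccc34)cc2)cc1`: > 100000 nM, a limit of the assay

Compound 2 has no number and sits at the limit of > 100000 nM in this assay, at which 1 of the 2 values shown sits. Compound 3 `O=S(=O)(/C=C/c1ccc(Cl)c(Cl)c1)Cc1ccc(Nc2ncnc3ccccc23)cc1` carries 3,4-dichlorophenyl in place of 4-cyanophenyl on a double-bonded chain carbon bound to a double-bonded chain carbon. Among the compounds with values here, the only measured step that bears on this is an at least 1.3-fold higher number from compound 1 to compound 2 (0.13 log units; that floor lies within the scatter), with cyano in place of hydrogen on an aromatic carbon. Within the data shown here, compound 1, at 74000 nM, is the only firm number, so a modest move to a lower number is expected in this assay. The expected change is an at least 1.6-fold lower number from compound 2 to compound 3 (0.22 log units; that floor lies within the scatter). For compound 3 the estimate is 60000 nM, with an expected range of 15000 nM to 120000 nM.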

Compound 3, concentration for 50% growth inhibition: 28000 nM
Beside the measured number, compound 3's estimate is 2.1-fold (0.33 log units) above it; measured number inside the range.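

In this assay, the change at this place on a double-bonded chain carbon now gives a firm step beyond the scatter: 3,4-dichlorophenyl in place of phenyl gives a 2.6-fold lower number from compound 1 to compound 3 (0.42 log units; beyond the scatter). Set against 4-cyanophenyl, the same group gives an at least 3.5-fold lower number from compound 2 to compound 3 (0.55 log units; beyond the scatter). Compound 2 carries only a limit, and the step from it is a floor: the limit of > 100000 nM in this assay, at which 1 of the 3 values shown sits.

The compounds shown leave open whether a single chlorine would move the number as far as the pair does. They also leave open how a methoxy group or an amine on that aromatic ring would read.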